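Phenyl in place of 4,5-dimethylfuran-2-yl on a carbonyl carbon

A few compounds are considered here, and "the series" means these few. Any claim that something is new, unique, unknown or untested is made for them only; others in the source may bear on it.

Going by the values given here, in a functional assay on HCT-116 cells (Homo sapiens) for antiproliferative activity, read by resazurin assay, with a stated time of 5 days (a higher number here means a weaker inhibitor, a lower number a stronger inhibitor), compound 2 `Cc1cc(C(=O)NCc2ccc3cc(C(=O)NO)sc3c2F)oc1C` gives 470 nM and holds the higher of the two numbers so far, while compound 1 `O=C(NCc1ccc2cc(C(=O)NO)sc2c1F)c1ccco1` gives 90 nM as the lower. Compound 3 `O=C(NCc1ccc2cc(C(=O)NO)sc2c1F)c1ccccc1` is not yet measured and carries phenyl in place of 4,5-dimethylfuran-2-yl on a carbonyl carbon, counted as phenyl in place of 4,5-dimethylfuran-2-yl on a carbonyl carbon in full. Among the compounds with values here, only one measured step bears on this place, and it is modest and beyond the scatter: a 5.2-fold higher number from compound 1 to compound 2 (0.72 log units; beyond the scatter) on going to 4,5-dimethylfuran-2-yl from furan-2-yl. Phenyl itself has no measured precedent, so that step is only a rough guide. A somewhat smaller step toward a lower number is expected in this assay for compound 3. The estimate corresponds to a 2.8-fold lower number from compound 2 to compound 3 (0.44 log units; beyond the scatter) as the expected change. For compound 3 the estimated value is 170 nM (expected range 50 nM to 500 nM).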

Compound 3, half-maximal inhibitory concentration: 980 nM
The estimate for compound 3 lay 5.8-fold (0.76 log units) below the measured number; the measured number lies above the stated range.
By their numbers in this assay, from the lowest: compound 1; then compound 2; then compound 3.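

Phenyl in place of 4,5-dimethylfuran-2-yl on the carbonyl carbon gives a 2.1-fold higher number from compound 2 to compound 3 (0.32 log units; beyond the scatter) in this assay, so the number at this place does not return toward that of the unsubstituted furan once the methyl-bearing ring is gone. Phenyl in place of furan-2-yl gives an 11-fold higher number from compound 1 to compound 3 (1.04 log units; beyond the scatter), a large step, which shows that this place responds to a change of the ring itself and not only to added methyl groups on the furan. No measurement bearing on the cause of this order is available.

On these data alone, it remains open whether the low number belongs to furan-2-yl alone or extends to another five-membered aromatic ring such as thiophen-2-yl. As far as these compounds go, a single methyl on the furan, and a non-aromatic group such as cyclohexyl on the same carbonyl carbon, also remain open.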